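Swapping one side chain on a growth inhibitor

The source may hold more compounds than are shown below. What is called first, only, known or untested is meant among the compounds shown, and "the series" means these compounds.

In a functional assay on MV4-11 cells (Homo sapiens) for inhibition, read by resazurin assay, with a stated time of 72 h (on this read-out higher numbers stand for weaker inhibition of growth and lower numbers for stronger inhibition of growth), compound 1 `COCCOc1nc(C)c(-c2ccnc(Nc3ccc(OC)cc3OC)n2)s1` gives 1980 nM and compound 2 `CCCn1cc(-c2ccnc(Nc3ccc(OC)cc3OC)n2)c2ccccc21` gives 3620 nM on the same scale. These two values lie within the usual scatter of each other, so compound 1 stands level with compound 2. Compound 3 `COc1ccc(Nc2nccc(-c3sc(OC(C)C)nc3C)n2)c(OC)c1` keeps the core of compound 1. The change isopropyl in place of 2-methoxyethyl on an oxygen on an aromatic ring puts isopropyl in place of 2-methoxyethyl on an oxygen on an aromatic ring. For the measured compounds named here, no measured pair shows this swap, so only a small effect is assumed: the estimated 1.3-fold lower number from compound 1 to compound 3 (0.12 log units; within the scatter) stays within the scatter, with no clear direction. For compound 3 the expected value is 1500 nM with a likely range from 500 nM to 4500 nM in this test.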

Compound 3, concentration for 50% growth inhibition: 8690 nM
The estimate for compound 3 lay 5.8-fold (0.76 log units) below the measured number, outside the stated range (above it).
By their numbers in this assay, from the lowest: compounds 1 and 2 (each within the scatter of the next); then compound 3.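

In this assay the group on this oxygen clearly matters: isopropyl in place of 2-methoxyethyl weakens growth inhibition (a 4.4-fold higher number from compound 1 to compound 3 (0.64 log units; beyond the scatter)). Compounds 1 and 2 could not show this, as they differ in more than one place. No measurement here explains the loss.

Isopropyl differs from 2-methoxyethyl both in having no chain oxygen and in its shape, and these compounds cannot separate the two differences. Going by these compounds, how a longer chain ending in an amine would behave on this oxygen also remains open.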